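Isobutoxycarbonyl to propargyloxy: notes on compound 4

The compounds below may be only part of what the source reports. "The series", "measured", "known", "first", "only" and "open" are said of these compounds alone.

In a functional assay on the whole organism with Scenedesmus acutus as the target (a lower number here means a stronger inhibitor, a higher number a weaker inhibitor), compound 1 `O=C(O)c1cc(N2C(=O)C3=C(CCCC3)C2=O)c(F)cc1Cl` gives 759 nM, compound 2 `CCOC(=O)c1cc(N2C(=O)C3=C(CCCC3)C2=O)c(F)cc1Cl` gives 100 nM and compound 3 `CC(C)COC(=O)c1cc(N2C(=O)C3=C(CCCC3)C2=O)c(F)cc1Cl` gives 33.1 nM, the lowest of the three numbers. Ethyl in place of hydrogen on the oxygen next to the carbonyl group gives a 7.6-fold lower number from compound 1 to compound 2 (0.88 log units; beyond the scatter), and isobutyl in the same place gives a 23-fold lower number from compound 1 to compound 3 (1.36 log units; beyond the scatter). Isopropyl in place of methyl on the chain gives a 3.0-fold lower number from compound 2 to compound 3 (0.48 log units; beyond the scatter).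

Compound 4 `C#CCOc1cc(N2C(=O)C3=C(CCCC3)C2=O)c(F)cc1Cl` has not been measured. It carries propargyloxy in place of isobutoxycarbonyl on an aromatic carbon, ortho to a chloro group and para to a fluoro group (propargyloxy in place of isobutoxycarbonyl on an aromatic carbon). For the measured compounds named here, no measured step makes this exchange, so all three bear on it only indirectly. The two largest steps, a 7.6-fold lower number from compound 1 to compound 2 (0.88 log units; beyond the scatter) and a 23-fold lower number from compound 1 to compound 3 (1.36 log units; beyond the scatter), start from a hydrogen on oxygen, which compound 4 lacks, as do compound 2 and compound 3. Going by the values given here, the closest guide is therefore the smaller 3.0-fold lower number from compound 2 to compound 3 (0.48 log units; beyond the scatter), which shows only that modest changes in this group register in this assay. No firm direction can be expected, so the working expectation is no step beyond the scatter, with wide uncertainty. The expected change is a 1.1-fold lower number from compound 3 to compound 4 (0.04 log units; within the scatter). For compound 4 the estimated value is 30 nM, with an expected range of 5 nM to 200 nM.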

Compound 4, half-maximal inhibitory concentration: 15.9 nM
The estimate for compound 4 lay 1.9-fold (0.28 log units) above the measured number; low and high end bracket the measured number.
By their numbers in this assay, from the lowest: compound 4; then compound 3; then compound 2; then compound 1.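

In this assay, propargyloxy in place of isobutoxycarbonyl on this aromatic carbon gives a 2.1-fold lower number from compound 3 to compound 4 (0.32 log units; beyond the scatter), so a carbonyl group in the substituent is not required at this position for a low number. The comparisons with the other two compounds point the same way, with a 6.3-fold lower number from compound 2 to compound 4 (0.80 log units; beyond the scatter) and a 48-fold lower number from compound 1 to compound 4 (1.68 log units; beyond the scatter), the latter the largest step in the set, and compound 4 now holds the lowest number of the four. Among the esters, the number fell from the ethyl to the isobutyl ester, but compound 4 goes against any reading that more bulk here gives a lower number, since propargyloxy has fewer heavy atoms than isobutoxycarbonyl.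

The compounds offer no measurement that accounts for these steps. Going by these compounds, it remains open whether the triple bond or the ether oxygen matters more, a question that allyloxy, propoxy or methoxy on the same aromatic carbon would address, while an amine link in place of the oxygen would test the linking atom itself.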